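A fluoro step among limits

The compounds below may be only part of what the source reports. "The series", "measured", "known", "first", "only" and "open" are said of these compounds alone.

In an ADME assay on MT4 cells (Homo sapiens) for cytotoxicity, read by MTT assay (a lower number here means that less compound is tolerated, a higher number that more compound is tolerated), compound 3 `CCc1c(Cc2c(F)cccc2Cl)nc(SCC(=O)c2ccccc2)[nH]c1=O` gives > 12000 nM, which is a limit and not a number. Compound 1 `O=C(CSc1nc(Cc2c(F)cccc2Cl)cc(=O)[nH]1)c1ccc(F)cc1` also stands at a limit, > 61000 nM. Compound 2 `Cc1c(Cc2c(F)cccc2Cl)nc(SCC(=O)c2ccc(F)cc2)[nH]c1=O`, which carries the 4-fluorophenyl group, likewise stands at a limit, > 59000 nM. None of the three therefore has a number, and compound 3 cannot be ranked against the other two.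

Compound 4 `CCc1c(Cc2c(F)cccc2Cl)nc(SCC(=O)c2ccc(F)cc2)[nH]c1=O` differs from compound 3 by fluoro in place of hydrogen on an aromatic carbon, with fluoro in place of hydrogen on an aromatic carbon, turning phenyl into 4-fluorophenyl. Among the measured compounds shown here, the only measured step, a step that the two limits leave unreadable from compound 1 to compound 2, is a different change, methyl in place of hydrogen on an aromatic carbon. It gives no size to carry over, so no step beyond the usual scatter is expected, and another limit is the likeliest report.

The expected step is a step that the limit leaves unreadable from compound 3 to compound 4. Compound 4 is estimated at 45000 nM, with an expected range of 12000 nM to 120000 nM.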

Compound 4, half-maximal cytotoxic concentration: > 57000 nM
Compound 4 ended at the assay's limit; the forecaster's own chance of this, stated with the estimate: 80%; at least 1.2-fold (0.10 log units) between middle value and limit.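

In this assay compound 4 gives > 57000 nM, which is a limit and not a number, so its steps from compound 1, compound 2 and compound 3 cannot be read. The compounds shown leave open whether fluoro in place of hydrogen on an aromatic carbon changes the tolerated concentration at all.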